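The source may report more compounds than this note shows. Statements on the series, on what has been measured and on what is new or still open speak of the compounds shown alone.

Among the compounds with values here, compound 2 `CN(C)C(=O)c1cc2cnc(Nc3ccc(C(=O)NCCCCN=C=S)cc3F)nc2n1C1CCCC1` gives 28.7% in a functional assay on NCI-H1299 cells (Homo sapiens) for inhibition, read by CCK-8 assay, with a stated time of 72 h, tested at 1 uM (a lower number here means a weaker effect, a higher number a stronger effect of the compound at the concentration tested), and stands lowest of the two numbers known so far. Its nearest neighbour, compound 1 `CN(C)C(=O)c1cc2cnc(Nc3ccc(C(=O)NCCCCCN=C=S)cc3)nc2n1C1CCCC1`, gives 50.3% in this assay, a reading beyond the scatter above that of compound 2. Within the data shown here, the two measured compounds differ in more than one place, so no single step between them is given, and their two values show only that the two structures together move the read-out.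

Compound 3 `CN(C)C(=O)c1cc2cnc(Nc3ccc(C(=O)NCCCCCN=C=S)cc3F)nc2n1C1CCCC1` has not yet been measured. Its difference from compound 2 is a single change, (a group of 4 heavy atoms (2 carbon, 1 nitrogen, 1 sulfur; no ring) in place of a group of 3 heavy atoms (1 carbon, 1 nitrogen, 1 sulfur; no ring), on a saturated chain carbon, four bonds along the chain from an amide-type nitrogen). Among the measured compounds shown here, the group that enters is the one that compound 1 carries at that place, and compound 3 keeps the rest of compound 2 unchanged.

On these two values alone the size of the step is uncertain. Compound 3 is expected to move upward from compound 2, with an estimated step of a number 13.3 percentage points higher from compound 2 to compound 3 (beyond the scatter) in this assay, which is judged to fall beyond the scatter but short of the reading of compound 1. Compound 3 is therefore estimated at 42% in this assay, within a range from 25% to 60%.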

Compound 3, a percentage reported as inhibition, at one concentration (the size of the read-out at that concentration, not a potency): 36.1%
For compound 3 the middle estimate is 5.9 percentage points above the measured one; measured number inside the range.
By their numbers in this assay, from the lowest: compounds 2 and 3 (each within the scatter of the next); then compound 1.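

In this assay, the group of 4 heavy atoms in place of the group of 3 heavy atoms on the saturated chain carbon gives a number 7.4 percentage points higher from compound 2 to compound 3 (within the scatter), so at this place the change does not separate the two compounds. Fluoro in place of hydrogen on an aromatic carbon, now readable as a single change, gives a number 14.2 percentage points lower from compound 1 to compound 3 (beyond the scatter), so the earlier gap between two compounds differing in more than one place can be followed to a single change that lies beyond the scatter, while the chain change stays within it. Nothing available on these compounds explains the size of either step.

The compounds shown leave open whether a longer chain, or an amine at the same place on the chain, would give a reading beyond the scatter, since only two chain groups appear here and both carry the same kind of end group. They also leave open whether chloro or methoxy in place of fluoro on that aromatic carbon would give a step like the one seen for fluoro, and whether the chain step would stay within the scatter on a compound without fluoro.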